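This account rests on a few compounds, and the source may have more. Where it says the series, first, only, none or still open, it means among the compounds named here.

Working notes on the shared core of compound 1 `C/N=c1/c(C#N)c2n(c(=O)n1-c1ccccc1)CCC2`, varied at the saturated chain carbon bound to a double-bonded nitrogen. In a functional assay on the whole organism (strain albino) for inhibition, with Rattus norvegicus as the target, read by paw edema, with a stated time of 4 h, at a dose of 0.029 mmol/kg by the oral route (on this read-out lower numbers stand for less inhibition and higher numbers for more inhibition at the one dose given (going by the name of the read-out)), compound 1 gives 1.27%. Compound 2 `CC/N=c1/c(C#N)c2n(c(=O)n1-c1ccccc1)CCC2` gives 1.11% in this assay. Compound 3 `C=CC/N=c1/c(C#N)c2n(c(=O)n1-c1ccccc1)CCC2` gives 0.52% in this assay. The three steps of a number 0.2 percentage points lower from compound 1 to compound 2 (within the scatter), a number 0.8 percentage points lower from compound 1 to compound 3 (within the scatter) and a number 0.6 percentage points lower from compound 2 to compound 3 (within the scatter) all sit within the scatter, so the three measured compounds are not separated from one another. As the numbers read, compound 3 stands at the low end of the three, yet its nearest neighbour compound 2 and its furthest neighbour compound 1 both lie within the scatter of it, and no ranking follows.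

Next in the series is compound 4 `CCCC/N=c1/c(C#N)c2n(c(=O)n1-c1ccccc1)CCC2`: propyl in place of vinyl on a saturated chain carbon bound to a double-bonded nitrogen. Within the data shown here, the steps that bear on this change are the ones made at the same place, a number 0.2 percentage points lower from compound 1 to compound 2 (within the scatter), a number 0.8 percentage points lower from compound 1 to compound 3 (within the scatter) and a number 0.6 percentage points lower from compound 2 to compound 3 (within the scatter); each stayed within the scatter and the values cluster closely. No step beyond the scatter is therefore expected in this assay. The expected step is a number 0.3 percentage points higher from compound 3 to compound 4 (within the scatter), which is to say no change of note. Compound 4 is estimated at 0.8% in this assay, with a range of -6% to 8%.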

Compound 4, a percentage reported as inhibition, in the whole organism at one dose (the size of the read-out at that dose, not a potency): 0.81%
Compound 4: the middle estimate sits 0 percentage points below what was measured, and the stated range covers the measured number.
By their numbers in this assay, from the lowest: compounds 3, 4, 2 and 1 (each within the scatter of the next).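

In this assay the swap of vinyl for propyl at this place gives a number 0.3 percentage points higher from compound 3 to compound 4 (within the scatter), so a chain with no double bond outside aromatic rings and one with such a bond are not separated here. The same holds against the shorter saturated chains, with a number 0.3 percentage points lower from compound 2 to compound 4 (within the scatter) and a number 0.5 percentage points lower from compound 1 to compound 4 (within the scatter), so all four compounds on the shared core remain unresolved on a saturated chain carbon bound to a double-bonded nitrogen, and the added carbon atoms of propyl bring no step beyond the scatter. Nothing available explains this flat result or says anything about the cause of it.

Still open is whether a group of a different kind at this place, such as an amine, a carboxylic acid or a phenyl ring, would move the number beyond the scatter, since every group shown is a small hydrocarbon chain. From the compounds shown here alone, a longer chain than propyl is equally open, and the single dose and single time point leave any difference among compound 1, compound 2, compound 3 and compound 4 at other doses unknown.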